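The compounds below may be only part of what the source reports. "The series", "measured", "known", "first", "only" and "open" are said of these compounds alone.

In an ADME assay on MT4 cells (Homo sapiens) for cytotoxicity, with a stated time of 5 days (a lower number here means that less compound is tolerated, a higher number that more compound is tolerated), compound 1 `CC1CC=C(C(=O)N(c2cc(C#CC(C)(C)C)sc2C(=O)O)C(C)C)CC1` gives > 20000 nM, which is a limit of the assay and not a number. Compound 3 `CC(C)(C)C#Cc1cc(N(C(=O)[C@H]2CC[C@H](C)CC2)[C@H]2CC[C@@H](Oc3ccc(=O)[nH]n3)CC2)c(C(=O)O)s1` gives > 20000 nM, again a limit. Compound 2 `CC(C)(C)C#Cc1cc(N(C(=O)[C@H]2CC[C@H](C)CC2)[C@H]2CC[C@](O)(CO[C@H]3CCOC3)CC2)c(C(=O)O)s1` gives > 20000 nM, also a limit. It therefore stands with the other two at the limit of > 20000 nM in this assay, at which 3 of the 3 values shown sit. Compound 4 `CC1=CC[C@H](C(=O)N(c2cc(C#CC(C)(C)C)sc2C(=O)O)[C@H]2CC[C@](O)(CO[C@H]3CCOC3)CC2)CC1` has 4-methylcyclohex-3-en-1-yl in place of 4-methylcyclohexyl on a carbonyl carbon. Among the compounds with values here, no pair of measured compounds gives the size of such a change, so no shift beyond the scatter is expected in this assay. The expected step, a number no higher from compound 2 to compound 4 (the limit leaves the size open), is correspondingly small. For compound 4 the estimated value is 20000 nM, with an expected range from 10000 nM to 40000 nM.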

Compound 4, half-maximal cytotoxic concentration: > 20000 nM
Compound 4 ended at the assay's limit; the forecaster's own chance of this, stated with the estimate: 85%; the middle value sits exactly at the limit.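

In this assay, compound 2 and compound 4 both stand at a limit, and no step can be read between them. The compounds shown leave open at what concentration any of them becomes cytotoxic, and whether 4-methylcyclohex-3-en-1-yl in place of 4-methylcyclohexyl changes that concentration.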